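A Methoxybenzyl in Place of a Phenyl on the Ring Amine

This account rests on a few compounds, and the source may have more. Where it says the series, first, only, none or still open, it means among the compounds named here.

Of the compounds shown here, three sharing one core have been measured in a functional assay on MCF7 cells (Homo sapiens) for cytotoxicity, read by MTT assay, with a stated time of 24 h, tested at 1.6 ug/mL; a lower number here means a weaker effect, a higher number a stronger effect of the compound at the concentration tested: compound 1 `Cc1nnc(SCC(=O)Nc2ccc(-c3nc(-c4ccccc4)c(-c4ccccc4)n3C)cc2)s1` gives 37.5%; compound 2 `Cn1ccnc1SCC(=O)Nc1ccc(-c2nc(-c3ccccc3)c(-c3ccccc3)n2C)cc1` gives 17.5%; compound 3 `Cn1c(-c2ccc(NC(=O)CN3CCN(c4ccccc4)CC3)cc2)nc(-c2ccccc2)c1-c1ccccc1` gives 21.3%.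

Compound 3 stands second highest of the three; its nearest neighbour is compound 2, with a number 3.8 percentage points higher from compound 2 to compound 3 (within the scatter), while a number 16.2 percentage points lower from compound 1 to compound 3 (beyond the scatter) lies beyond the scatter. Compound 4 `COc1ccc(CN2CCN(CC(=O)Nc3ccc(-c4nc(-c5ccccc5)c(-c5ccccc5)n4C)cc3)CC2)cc1` differs from compound 3 by 4-methoxybenzyl in place of phenyl on an amine nitrogen in a ring. Among the measured compounds shown here, no measured step touches this ring amine nitrogen; the steps of a number 20 percentage points lower from compound 1 to compound 2 (beyond the scatter) and a number 16.2 percentage points lower from compound 1 to compound 3 (beyond the scatter) replace the whole group on the chain carbon instead, so they give no direct guide. The expected step of a number 0.7 percentage points higher from compound 3 to compound 4 (within the scatter) is therefore none beyond the scatter. Compound 4 is estimated at 22%, within 10% to 38%.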

Compound 4, a percentage reported as activity, at one concentration (the size of the read-out at that concentration, not a potency): 27.3%
Estimate against measurement, compound 4: 5.3 percentage points below, and the stated range covers the measured number.
By their numbers in this assay, from the lowest: compounds 2, 3 and 4 (each within the scatter of the next); then compound 1.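

Among the compounds shown here, compound 3 and compound 4 give the first measured step at this ring amine nitrogen: in this assay, 4-methoxybenzyl in place of phenyl gives a number 6 percentage points higher from compound 3 to compound 4 (within the scatter) at this position. The entering group adds heavy atoms and a hydrogen-bond acceptor, yet this single-concentration read-out does not separate the two compounds. No evidence bears on this result.

The compounds shown leave open what a plain benzyl or a methyl on this nitrogen would give. They also cannot separate the methoxy group from the added carbon link.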